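The compounds below may be only part of what the source reports. "The series", "measured", "known", "first", "only" and "open" are said of these compounds alone.

In an ADME assay on RAW264.7 cells (Mus musculus) for cytotoxicity, read by MTT assay, with a stated time of 72 h, tested at 50 uM (on this read-out higher numbers stand for more inhibition at the one concentration tested (going by the name of the read-out) and lower numbers for less inhibition), compound 2 `CCOC(=O)c1sc(-c2ccncc2)nc1N1CCC(NCc2ccccc2)CC1` gives 10.8%, and compound 1 `CCOC(=O)c1sc(-c2ccccc2)nc1N1CCC(NCc2ccc(OC)cc2)CC1` gives 8.4%, a number within the usual scatter of it, so the two cannot be told apart; both show little inhibition at the single concentration tested. Compound 3 `CCOC(=O)c1sc(-c2ccncc2)nc1N1CCC(NCc2ccc(OC)cc2)CC1` differs from compound 2 by methoxy in place of hydrogen on an aromatic carbon. Among the measured compounds shown here, no step between measured compounds isolates this change, so nothing recorded bears on its size. The step of a number 0.8 percentage points lower from compound 2 to compound 3 (within the scatter) is expected to be none beyond the scatter. Compound 3 is estimated to give 10%, between 0% and 22%.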

Compound 3, a percentage reported as inhibition, at one concentration (the size of the read-out at that concentration, not a potency): 16.1%
Compound 3: the middle estimate sits 6.1 percentage points below what was measured, and the stated range covers the measured number.
By their numbers in this assay, from the lowest: compounds 1, 2 and 3 (each within the scatter of the next).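

In this assay the change from benzyl to 4-methoxybenzyl gives a number 5.3 percentage points higher from compound 2 to compound 3 (within the scatter) and thus has no effect that can be told from the scatter at this place. Pyridin-4-yl in place of phenyl, with the 4-methoxybenzyl group kept, gives a number 7.7 percentage points higher from compound 1 to compound 3 (within the scatter) and so also stays inside the scatter. Nothing on hand offers a reason for either step. On these data alone, whether a chlorine atom or a dimethylamino group at this place on the benzyl group would give a step beyond the scatter remains open. So does the effect of a carboxylic acid in place of the ethyl ester.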